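Pyridin-3-yl in Place of Thiophen-2-yl: An Expected Step

A few compounds are considered here, and "the series" means these few. Any claim that something is new, unique, unknown or untested is made for them only; others in the source may bear on it.

Compound 1 `CCN(c1ccc(C#N)c(Cl)c1)c1cc(-c2cccs2)ccc1C`: 22000 nM
Compound 2 `CCN(c1ccc(C#N)c(Cl)c1)c1cc(-c2cnc3ccccc3c2)ccc1C`: "not determined" (no result reported)
Compound 3 `CCN(c1cccc(-c2ccccc2)c1)c1ccc(C#N)c(Cl)c1`: "not determined" (no result reported)

Three compounds share a diarylamine core built around a chlorinated nitrile-bearing ring. Within the data shown here, in a functional assay on CWR22R cells (Homo sapiens) for antiproliferative activity, read by CCK-8 assay, with a stated time of 6 days (on this read-out lower numbers stand for stronger inhibition and higher numbers for weaker inhibition), compound 1 gives 22000 nM, and this is the only number available in the set: compound 2 and compound 3 carry no result in this assay, so compound 1 stands alone, with nothing to rank it against. Its value itself is a weak one for an antiproliferative read-out.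

Compound 4 `CCN(c1ccc(C#N)c(Cl)c1)c1cc(-c2cccnc2)ccc1C` differs from compound 1 in a single place: pyridin-3-yl in place of thiophen-2-yl on an aromatic carbon. The five-membered aromatic ring with one hetero atom gives way to a six-membered aromatic ring with one hetero atom, the count of hydrogen-bond acceptors staying at one and the net charge at zero. Among the measured compounds shown here, no step between two measured compounds exists in this set to indicate what such an exchange does, so the expectation can rest only on the value of compound 1 and on the modest size of the change. The step from compound 1 to compound 4 is expected to be small, a 1.1-fold lower number from compound 1 to compound 4 (0.04 log units; within the scatter), in no direction that goes beyond the usual scatter. Compound 4 is therefore estimated at 20000 nM, within a range of 7000 nM to 60000 nM.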

Compound 4, half-maximal inhibitory concentration: 2000 nM
Estimate against measurement, compound 4: 10-fold (1.00 log units) above, outside the stated range (below it).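

In this assay, pyridin-3-yl in place of thiophen-2-yl on this aromatic carbon, meta to a large group and para to a methyl group, gives an 11-fold lower number from compound 1 to compound 4 (1.04 log units; beyond the scatter). This shows what compound 1 standing alone could not: the group at this position can move the read-out well beyond the usual scatter, and a change of a single aromatic ring is enough to do so. The step comes with the same counts of hydrogen-bond donors and acceptors and no net charge on either side, so those counts do not separate the two groups, and nothing measured here explains the size of the step.

The compounds shown do not tell whether the gain follows the ring nitrogen or the six-membered ring as such, a question that a plain phenyl group at this place would address. They also leave open how pyridin-2-yl, pyridin-4-yl or a pyridine ring carrying an amine would compare here, and so whether the nitrogen's place in the ring matters at all.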